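Alkoxy size at the aryl ether: compound 1 to compound 4

A few compounds are considered here, and "the series" means these few. Any claim that something is new, unique, unknown or untested is made for them only; others in the source may bear on it.

Measured so far:
compound 1 `COc1cc(-n2ncnc2-c2ccc(OC(C)C)cc2)cc(OC)c1OC` — 650 nM
compound 2 `CCOc1ccccc1-c1ncnn1-c1cc(OC)c(OC)c(OC)c1` — > 10000 nM
compound 3 `CCOc1cccc(-c2ncnn2-c2cc(OC)c(OC)c(OC)c2)c1` — > 10000 nM

For the measured compounds named here, in a functional assay on Jurkat cells (Homo sapiens) for antiproliferative activity, read by MTT assay, with a stated time of 72 h (a lower number here means a stronger inhibitor, a higher number a weaker inhibitor), compound 1 gives 650 nM, the only plain number among the three measured compounds. Compound 2 reaches only the limit of this assay, > 10000 nM. Compound 3 likewise stops at the limit, > 10000 nM. Two of the three values thus sit at the limit of > 10000 nM in this assay, at which 2 of the 3 values shown sit, and compound 1 alone stands clear of it.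

Compound 4 `CCOc1ccc(-c2ncnn2-c2cc(OC)c(OC)c(OC)c2)cc1` has not yet been measured in this assay. It differs from compound 1 by hydrogen in place of methyl on a saturated chain carbon bound to an oxygen on an aromatic ring and a saturated chain carbon. Going by the values given here, no two measured compounds differ in a single place, so there is no measured step to show how large such a change runs; compound 2 and compound 3 carry ethoxy as well, but on other positions of the ring, and only show the limit.

For compound 4 the expectation is a step of a 2.3-fold higher number from compound 1 to compound 4 (0.36 log units; beyond the scatter) in this assay, a modest loss toward weaker inhibition, possibly within the usual scatter. Compound 4 is estimated at 1500 nM, with a range from 450 nM to 6000 nM.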

Compound 4, half-maximal inhibitory concentration: 5 nM
The estimate for compound 4 lay 300-fold (2.48 log units) above the measured number; measured number below the stated range.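

In this assay, for the compounds shown here, the change from isopropoxy to ethoxy gives a 130-fold lower number from compound 1 to compound 4 (2.11 log units; beyond the scatter), so this position responds strongly to the removal of one methyl, something the earlier compounds could not show, as no two of them differed in a single place. Ethoxy alone does not guarantee such a number: in this assay compound 2 gives > 10000 nM, which is a limit of the assay. Compound 3, which also carries ethoxy, likewise stops at a limit, > 10000 nM.

Nothing shown gives a cause for the size of this step. Going by these compounds, it remains open whether methoxy, a hydroxyl, or a longer straight chain such as propoxy would keep the number of compound 4 or lose it, and so whether ethoxy is a narrow optimum or one point on a broader trend.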